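The source may report more compounds than this note shows. Statements on the series, on what has been measured and on what is new or still open speak of the compounds shown alone.

Measured in a physicochemical assay for lipophilicity, at pH 7.4; on this read-out higher numbers stand for higher lipophilicity and lower numbers for lower lipophilicity:
- compound 1 `COc1cc2[nH]c(C)c(C3CCCCC3)c(=O)c2cc1Cl`: 3.04
- compound 2 `CCCCC#Cc1c(C)[nH]c2cc(OC)c(Cl)cc2c1=O`: 2.45

Of these two, compound 2 holds the lower number, and its gap to compound 1 lies beyond the scatter. Compound 3 `C=C(CCCCC)c1c(C)[nH]c2cc(OC)c(Cl)cc2c1=O` has not been measured and differs from compound 2 by a group of 7 heavy atoms (7 carbon; no ring) in place of a group of 6 heavy atoms (6 carbon; no ring), on an aromatic carbon. Among the measured compounds shown here, one measured step bears on this change: a number 0.59 log units lower from compound 1 to compound 2 (beyond the scatter), a modest step beyond the scatter. It also exchanges the group on an aromatic carbon, with hex-1-yn-1-yl as the incoming group. For the measured compounds named here, a single step is thin support, and no measured step starts from hex-1-yn-1-yl. Since compound 1 stands higher at 3.04, a modest rise in this assay is expected on leaving hex-1-yn-1-yl, of about that size. The expected change is a number 0.60 log units higher from compound 2 to compound 3 (beyond the scatter). For compound 3 the estimated value is 3.05, within an expected range of 2.65 to 3.45.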

Compound 3, distribution coefficient: 3.58
Compound 3: middle estimate off by 0.53 log units, on the low side; the whole stated range lies below it.
By their numbers in this assay, from the lowest: compound 2; then compound 1; then compound 3.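

In this assay, the group on this aromatic carbon, two atoms from the ring nitrogen, can move the number a long way with the shared core unchanged: replacing hex-1-yn-1-yl with the open-chain group carrying a double bond gives a number 1.13 log units higher from compound 2 to compound 3 (beyond the scatter), a large step. The same group also stands over cyclohexyl, with a number 0.54 log units higher from compound 1 to compound 3 (beyond the scatter), so the open-chain groups do not sit together on one side of the ring: hex-1-yn-1-yl lies under cyclohexyl and the group of compound 3 over it. Cyclohexyl therefore marks the middle of the three groups at this position, not its top.

As far as these compounds go, how an amine, a carboxylic acid or a longer chain on this aromatic carbon would stand against these three groups remains open. Nothing available accounts for the size of either step.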